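Compound 4, the mirror image of compound 3

The source may hold more compounds than are shown below. What is called first, only, known or untested is meant among the compounds shown, and "the series" means these compounds.

Compound 3 `CCCCCCCCc1ccc(NC(=O)[C@H](N)[C@@H](C)O)cc1` gives 1600 nM in an assay on isolated protein for inhibition of sphingosine kinase 1 (Homo sapiens), read by mobility shift assay (on this read-out lower numbers stand for stronger inhibition and higher numbers for weaker inhibition), the smallest of the three numbers shown, although compound 2 `CCCCCCCCc1ccc(NC(=O)[C@H](N)[C@H](C)O)cc1` at 2100 nM and compound 1 `CCCCCCCCc1ccc(NC(=O)[C@H](CO)NC)cc1` at 2800 nM both lie within the scatter of it. Compound 4 `CCCCCCCCc1ccc(NC(=O)[C@@H](N)[C@H](C)O)cc1` differs from compound 3 in that (the two compounds have the same atoms and bonds and differ only in configuration as drawn: 2 of 2 stereo elements differ (all stereocentres are inverted: mirror images); a stereocentre at a saturated chain carbon is drawn R in compound 3 and S in compound 4; a stereocentre at a saturated chain carbon is drawn R in compound 3 and S in compound 4). The measured step that bears on this is a 1.3-fold lower number from compound 2 to compound 3 (0.12 log units; within the scatter), where the fact that compounds 2 and 3 differ only in the configuration as drawn shows that inverting a single stereocentre moved the number no further than the scatter. The steps of a 1.3-fold lower number from compound 1 to compound 2 (0.12 log units; within the scatter) and a 1.8-fold lower number from compound 1 to compound 3 (0.24 log units; within the scatter) were likewise within the scatter. Compound 4 is therefore expected to stay close to compound 3, with a 1.6-fold higher number from compound 3 to compound 4 (0.19 log units; within the scatter) expected to remain within the scatter. Compound 4 is estimated at 2500 nM, with a range from 900 nM to 7000 nM.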

Compound 4, half-maximal inhibitory concentration: 1100 nM
For compound 4 the middle estimate is 2.3-fold (0.36 log units) above the measured one, and the stated range covers the measured number.
By their numbers in this assay, from the lowest: compounds 4, 3, 2 and 1 (each within the scatter of the next, the first and the last beyond it).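

Inverting both stereocentres together in this assay stays within the scatter, with a 1.5-fold lower number from compound 3 to compound 4 (0.16 log units; within the scatter): the fact that compounds 3 and 4 differ only in the configuration as drawn. Inverting the other stereocentre alone also stays within it, with a 1.9-fold lower number from compound 2 to compound 4 (0.28 log units; within the scatter): the fact that compounds 2 and 4 differ only in the configuration as drawn. Within the data shown here, the only step beyond the scatter here is the modest 2.5-fold lower number from compound 1 to compound 4 (0.41 log units; beyond the scatter), with 1-amino-2-hydroxypropyl in place of 2-hydroxy-1-(methylamino)ethyl on a carbonyl carbon.

Open, on these data alone, is whether that step follows the methylamino group or the added methyl on the hydroxyl-bearing chain. Also open, as far as these compounds go, is how the number responds to a dimethylamino group, a methyl ether or a decyl chain.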